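The source may hold more compounds than are shown below. What is called first, only, known or untested is meant among the compounds shown, and "the series" means these compounds.

Among the measured compounds shown here, compound 2 `CS(=O)(=O)c1ccc(Cc2n[nH]c(=S)n2/N=C/c2c(F)cccc2Cl)cc1` stands highest of the two numbers so far in a functional assay on HeLa cells (Homo sapiens) for cytotoxicity, read by MTT assay, with a stated time of 48 h, tested at 50 uM (a lower number here means a weaker effect, a higher number a stronger effect of the compound at the concentration tested), giving 70.6%. For the measured compounds named here, the one compound it can be compared with, compound 1 `CS(=O)(=O)c1ccc(Cc2n[nH]c(=S)n2/N=C/c2ccc(Cl)cc2)cc1`, gives 54% in this assay, and the step of a number 16.6 percentage points higher from compound 1 to compound 2 (beyond the scatter) is the single measured change that bears on what follows. Compound 3 `CS(=O)(=O)c1ccc(Cc2n[nH]c(=S)n2/N=C/c2ccc(F)cc2)cc1` has not yet been measured; it differs from compound 2 by 4-fluorophenyl in place of 2-chloro-6-fluorophenyl on a carbon with a double bond to nitrogen. This change largely reverses what separates compound 1 from compound 2, returning to a phenyl ring that carries a single halogen, now as 4-fluorophenyl rather than 4-chlorophenyl. Since compound 1 with its 4-chlorophenyl sits at 54%, a step back towards that level is expected, of about a number 15.6 percentage points lower from compound 2 to compound 3 (beyond the scatter) in this assay. Compound 3 is therefore estimated to give 55%, with a range from 40% to 70%.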

Compound 3, a percentage reported as activity, at one concentration (the size of the read-out at that concentration, not a potency): 26.3%
Compound 3: the middle estimate sits 28.7 percentage points above what was measured, outside the stated range (below it).
By their numbers in this assay, from the lowest: compound 3; then compound 1; then compound 2.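

Among the compounds shown here, the halogen pattern on this ring matters more than the single step from compound 1 to compound 2 could show: in this assay, replacing 2-chloro-6-fluorophenyl with 4-fluorophenyl gives a number 44.3 percentage points lower from compound 2 to compound 3 (beyond the scatter). Carrying one halogen does not fix the read-out at one level, since the swap of fluoro for chloro on an aromatic carbon gives a number 27.7 percentage points lower from compound 1 to compound 3 (beyond the scatter), so the identity of that halogen counts here too. No supporting evidence is available to explain why these changes alter the effect on the cells.

The compounds shown leave open how a phenyl ring bearing a methoxy group or an amine in place of halogen would compare. They also leave open whether the chlorine, the fluorine or the pair carries the higher read-out of 2-chloro-6-fluorophenyl.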